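Aryl swap on the hydrazone carbon: compound 4

A few compounds are considered here, and "the series" means these few. Any claim that something is new, unique, unknown or untested is made for them only; others in the source may bear on it.

Three compounds share one core. In a functional assay on HT-29 cells (Homo sapiens) for cytotoxicity, read by MTT assay, with a stated time of 72 h (a higher number here means a weaker inhibitor, a lower number a stronger inhibitor), compound 1 `COc1ccc(OC)c(/C=N/NC(=O)Nc2ccc(Oc3ccnc(-c4nncn4CCN(C)C)c3)c(F)c2)c1` gives 2070 nM, compound 2 `CN(C)CCn1cnnc1-c1cc(Oc2ccc(NC(=O)N/N=C/c3ccc(O)c(O)c3)cc2F)ccn1` gives 1890 nM and compound 3 `CN(C)CCn1cnnc1-c1cc(Oc2ccc(NC(=O)N/N=C/c3ccc(O)cc3)cc2F)ccn1` gives 1920 nM. Compound 3 holds the second highest of the three numbers, yet every gap lies within the scatter: a 1.1-fold lower number from compound 1 to compound 3 (0.03 log units; within the scatter), a 1.0-fold higher number from compound 2 to compound 3 (0.01 log units; within the scatter) and a 1.1-fold lower number from compound 1 to compound 2 (0.04 log units; within the scatter). Compound 4 `COc1cc(/C=N/NC(=O)Nc2ccc(Oc3ccnc(-c4nncn4CCN(C)C)c3)c(F)c2)cc(OC)c1OC` differs from compound 3 in one place: 3,4,5-trimethoxyphenyl in place of 4-hydroxyphenyl on a carbon with a double bond to nitrogen. Among the measured compounds shown here, the steps that bear on this swap are the two earlier exchanges on the same carbon, a 1.1-fold lower number from compound 1 to compound 3 (0.03 log units; within the scatter) and a 1.1-fold lower number from compound 1 to compound 2 (0.04 log units; within the scatter), neither of which moved the number beyond the scatter, so no step beyond the scatter is expected in this assay now. The expected step is a 1.0-fold higher number from compound 3 to compound 4 (0.01 log units; within the scatter). Compound 4 is therefore estimated at 1950 nM, within 900 nM to 4200 nM.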

Compound 4, half-maximal inhibitory concentration: 3620 nM
Compound 4: middle estimate off by 1.9-fold (0.27 log units), on the low side; the measured number falls inside the stated range.
By their numbers in this assay, from the lowest: compounds 2, 3, 1 and 4 (each within the scatter of the next).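

Read in this assay, 3,4,5-trimethoxyphenyl on a carbon with a double bond to nitrogen stays within the scatter of all three earlier aryl groups, with a 1.9-fold higher number from compound 3 to compound 4 (0.28 log units; within the scatter) and a 1.9-fold higher number from compound 2 to compound 4 (0.28 log units; within the scatter) and with a 1.7-fold higher number from compound 1 to compound 4 (0.24 log units; within the scatter) as well. This position therefore accepts an aryl group of 12 heavy atoms with 0 hydrogen-bond donors without a step beyond the scatter. No measurement at hand accounts for this flat result. Still open, as far as these compounds go, is whether any group here gives a step beyond the scatter, for example a carboxylic acid or an amine on the phenyl ring.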